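Swapping the aryl tail of compound 1 for a thiophene

A few compounds are considered here, and "the series" means these few. Any claim that something is new, unique, unknown or untested is made for them only; others in the source may bear on it.

Of the compounds shown here, two have numbers so far in an assay on CHO cells for displacement of a labelled ligand from melanin-concentrating hormone receptor 1 (Homo sapiens), read by scintillation counting, with a stated time of 1 h; on this read-out lower numbers stand for stronger inhibition and higher numbers for weaker inhibition. Compound 1, with structure `Cc1c(C2CC2)nc2ccc(-n3ccc(OCc4ccc(C(C)C)cc4)cc3=O)cn12`, gives 410 nM in this assay. Compound 2, with structure `CCc1nc2ccc(-n3ccc(OCc4ccccc4)cc3=O)cn2c1C`, gives 120 nM in this assay. Of these two numbers, compound 1 carries the higher one, and the gap between it and compound 2 lies beyond the usual scatter of repeated measurements. Going by the values given here, compound 2 differs from compound 1 in more than one place, so no single step between them can be read.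

The next compound, compound 3, has structure `Cc1c(C2CC2)nc2ccc(-n3ccc(OCc4csc(C(F)(F)F)c4)cc3=O)cn12`. It keeps the core of compound 1 and changes only the aromatic tail: 5-(trifluoromethyl)thiophen-3-yl in place of 4-isopropylphenyl on a saturated chain carbon bound to an oxygen on an aromatic ring. Among the compounds with values here, no pair of measured compounds shows this change, so its effect here is unknown. The expectation is a step from compound 1 to compound 3 that is small and may stay within the scatter, written as a 1.5-fold lower number from compound 1 to compound 3 (0.17 log units; within the scatter). On that basis compound 3 is estimated to give 280 nM in this assay, with a range from 80 nM to 1000 nM.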

Compound 3, half-maximal inhibitory concentration: 17 nM
Beside the measured number, compound 3's estimate is 16-fold (1.22 log units) above it; measured number below the stated range.
By their numbers in this assay, from the lowest: compound 3; then compound 2; then compound 1.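

Going by these compounds alone, until now, no single change at this position could be read, so the earlier compounds gave no sign of how much the tail matters. With the core of compound 1 held fixed in this assay, putting 5-(trifluoromethyl)thiophen-3-yl in place of 4-isopropylphenyl on a saturated chain carbon bound to an oxygen on an aromatic ring gives a 24-fold lower number from compound 1 to compound 3 (1.38 log units; beyond the scatter), so this position can respond strongly to a change of tail. Both tails count 9 heavy atoms, so that count stays the same while a six-membered aromatic ring of carbon only gives way to a five-membered aromatic ring with 1 hetero atom, and no measurement shown explains the step.

On these data alone, the swap changes the ring and its substituent together, so it remains open whether the thiophene, the trifluoromethyl group or the pair of them accounts for the step, and a 4-(trifluoromethyl)phenyl tail or an unsubstituted thiophen-3-yl tail would help to separate them. As far as these compounds go, compound 2 differs from the other two compounds in more than one place, so its steps cannot be read, and it is also open how a tail carrying an amine or a carboxylic acid would fare here.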